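The source may hold more compounds than are shown below. What is called first, only, known or untested is meant among the compounds shown, and "the series" means these compounds.

Working notes on the series in a functional assay on the whole organism (stomach) with Rattus norvegicus as the target; a lower number here means that less compound is needed, a higher number that more compound is needed for the effect.

Three compounds have numbers. Compound 1 `C/N=C(\S)NCCCCCn1nc(-c2ccccc2)ccc1=O` gives 35.3 mg/kg. Compound 2 `CC/N=C(\S)NCCCCCn1nc(-c2ccccc2)ccc1=O` gives 51.8 mg/kg, and the change from compound 1 to compound 2 is a 1.5-fold higher number from compound 1 to compound 2 (0.17 log units; within the scatter). Compound 3 `CC/N=C(/NC#N)NCCCCn1nc(-c2ccccc2)ccc1=O` gives 92 mg/kg, the highest number of the three; the steps are a 2.6-fold higher number from compound 1 to compound 3 (0.42 log units; beyond the scatter) and a 1.8-fold higher number from compound 2 to compound 3 (0.25 log units; within the scatter).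

Compound 4 `CC/N=C(/NC#N)NCCCCn1nc(-c2ccccc2)c(C)cc1=O` differs from compound 3 in one place: methyl in place of hydrogen on an aromatic carbon, on the six-membered aromatic ring with 2 nitrogen of the shared core, ortho to the phenyl group and two atoms from the ring nitrogen.

Among the compounds with values here, no measured step in this assay touches an aromatic carbon of the core; every step so far alters the terminal group on the chain. Within the data shown here, the only comparison that concerns a methyl in place of hydrogen is a 1.5-fold higher number from compound 1 to compound 2 (0.17 log units; within the scatter), and there the methyl enters on a saturated chain carbon, not on the ring. That step stayed within the scatter. On this basis the step from compound 3 to compound 4 is expected to be no change at the digits printed from compound 3 to compound 4 (within the scatter), with no clear direction.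

For compound 4 the value in this assay is estimated at 92 mg/kg, with a range from 46 mg/kg to 184 mg/kg.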

Compound 4, dose for half-maximal effect: > 100 mg/kg
Compound 4: a limit, no number (the forecaster's own chance of this, stated with the estimate: 5%); middle value at least 1.0-fold (0.03 log units) from the limit.
By their numbers in this assay, from the lowest: compounds 1, 2 and 3 (each within the scatter of the next, the first and the last beyond it). At a limit, above all of these: compound 4.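

In this assay compound 4 gives > 100 mg/kg, which is a limit of the assay and not a number: the limit of > 100 mg/kg in this assay, at which 1 of the 4 values shown sits.

Within the data shown here, this is the first reading for a change on an aromatic carbon of the shared core, and methyl in place of hydrogen at this position, ortho to a phenyl group, gives an at least 1.0-fold higher number from compound 3 to compound 4 (0.03 log units; that floor lies within the scatter). Among these compounds, the only earlier methyl step, a 1.5-fold higher number from compound 1 to compound 2 (0.17 log units; within the scatter), concerned a saturated chain carbon, so the new result adds that the ring methyl brings no measurable gain: nothing shows that less compound is needed with it, though the floor of the step does not set it apart from the scatter.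

From the compounds shown here alone, how far the true figure for compound 4 lies from that of compound 3 stays open, so the size of the methyl effect at this carbon cannot be stated. Also open, going by these compounds, is how an ethyl group, a chlorine atom or a methoxy group would read at the same carbon, and whether the ring methyl would read the same way on the chain and terminal group of compound 1.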